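The compounds below may be only part of what the source reports. "The series", "measured", "known", "first", "only" and "open" are said of these compounds alone.

Measured so far in a functional assay on MCF7 cells (Homo sapiens) for inhibition, read by CCK-8 assay; a higher number here means a weaker inhibitor, a lower number a stronger inhibitor:
compound 1 `Cc1cccc(-c2nnc(CSc3nnc(/N=C/c4ccccc4O)s3)o2)c1` — 11600 nM
compound 2 `O=[N+]([O-])c1cccc(-c2nnc(CSc3nnc(/N=C/c4ccccc4O)s3)o2)c1` — 13900 nM

Compound 2 and compound 1 lie within the scatter of one another, so neither can be set above the other. Within the data shown here, the single measured step, a 1.2-fold higher number from compound 1 to compound 2 (0.08 log units; within the scatter), exchanged one group for another on the phenyl ring and stayed within the scatter.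

Compound 3 `O=[N+]([O-])c1ccc(-c2nnc(CSc3nnc(/N=C/c4ccccc4O)s3)o2)cc1` is next. It differs from compound 2 by 4-nitrophenyl in place of 3-nitrophenyl on an aromatic carbon. Among the measured compounds shown here, no measured step relocates a group on this ring, so only the group exchange in a 1.2-fold higher number from compound 1 to compound 2 (0.08 log units; within the scatter) offers any guide, and it was flat. Compound 3 is therefore expected near 13000 nM, between 6000 nM and 28000 nM. The step of a 1.1-fold lower number from compound 2 to compound 3 (0.03 log units; within the scatter) is expected to remain within the scatter.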

Compound 3, half-maximal inhibitory concentration: 4250 nM
Compound 3: the middle estimate sits 3.1-fold (0.49 log units) above what was measured; measured number outside the range, below it.
By their numbers in this assay, from the lowest: compound 3; then compounds 1 and 2 (each within the scatter of the next).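

Where the nitro group sits on the phenyl ring matters here: 4-nitrophenyl in place of 3-nitrophenyl gives a 3.3-fold lower number from compound 2 to compound 3 (0.51 log units; beyond the scatter) in this assay even though the two groups hold the same atoms. The 4-nitrophenyl group also separates from 3-methylphenyl, with a 2.7-fold lower number from compound 1 to compound 3 (0.44 log units; beyond the scatter) as the step, whereas the earlier exchange of methyl for nitro with the position unchanged stayed within the scatter. No supporting data are available to account for this result.

Still open, on these data alone, is whether 4-methylphenyl would read like 4-nitrophenyl or like 3-methylphenyl. Also open, as far as these compounds go, is how an amine or a carboxylic acid on the same phenyl ring would read.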